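Methyl in place of hydrogen at two nitrogen-bound chain carbons

The source may hold more compounds than are shown below. What is called first, only, known or untested is meant among the compounds shown, and "the series" means these compounds.

Compound 1 `CCCCc1oc2ccccc2c1C(=O)c1ccc(OCC(=O)NCc2ccccc2)cc1` is tested in a functional assay on MDA-MB-231 cells (Homo sapiens) for antiproliferative activity, read by MTT assay, with a stated time of 24 h; on this read-out lower numbers stand for stronger inhibition and higher numbers for weaker inhibition. In this assay compound 1 gives only a limit, > 50000 nM. Compound 2 `CCCCc1oc2ccccc2c1C(=O)c1ccc(OCC(=O)N[C@@H](C)c2ccccc2)cc1` carries methyl in place of hydrogen on a saturated chain carbon bound to an amide-type nitrogen and an aromatic carbon. In this assay compound 2 also gives only a limit, > 50000 nM. The step that the two limits leave unreadable from compound 1 to compound 2 therefore has no readable size, both values sitting at the limit of > 50000 nM in this assay, at which 2 of the 3 values shown sit.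

Compound 3 `CCCCc1oc2ccccc2c1C(=O)c1cc(I)c(OCCCN2CCN(C)CC2)c(I)c1` has a different core from compound 1; the difference between the two cores is not broken down here. In this assay, within the data shown here, compound 3 gives 8760 nM, the only plain number among the three measured compounds.

Compound 4 `CCCCc1oc2ccccc2c1C(=O)c1cc(I)c(OCCCN2CCN(CC)CC2)c(I)c1` is not yet measured. Relative to compound 3 it carries methyl in place of hydrogen on a saturated chain carbon bound to an amine nitrogen in a ring. This is the same kind of change as from compound 1 to compound 2, but the place differs: there the carbon is bound to an amide-type nitrogen and an aromatic carbon, here to an amine nitrogen in a ring. The measured pair offers no readable size for such a step. The step of a 1.2-fold lower number from compound 3 to compound 4 (0.07 log units; within the scatter) is expected to be small. Compound 4 is estimated at 7500 nM, with a range of 3000 nM to 20000 nM.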

Compound 4, half-maximal inhibitory concentration: 18000 nM
Estimate against measurement, compound 4: 2.4-fold (0.38 log units) below; the range from low to high includes it.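

On the core of compound 3, methyl in place of hydrogen on a saturated chain carbon bound to an amine nitrogen in a ring gives a 2.1-fold higher number from compound 3 to compound 4 (0.31 log units; beyond the scatter), a modest weakening in this assay. The same kind of change on the core of compound 1, at a carbon bound to an amide-type nitrogen and an aromatic carbon, cannot be read: the limit of > 50000 nM in this assay, at which 2 of the 4 values shown sit. The series thus gives one readable size for this change, at one place on one core, and it shows neither that the step carries over from one core to the other nor that it fails to.

Still open, from the compounds shown here alone, is whether the trend from methyl to ethyl continues with a longer chain, such as propyl in place of the ethyl of the 4-ethylpiperazin-1-yl group. Also open, going by these compounds, is whether the 4-methylpiperazin-1-yl and 4-ethylpiperazin-1-yl side chains would give plain numbers on the core of compound 1, which would allow a direct comparison between the cores.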